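This account rests on a few compounds, and the source may have more. Where it says the series, first, only, none or still open, it means among the compounds named here.

In a functional assay on OVCAR-3 cells (Homo sapiens) for inhibition, read by sulforhodamine B assay, with a stated time of 48 h (on this read-out lower numbers stand for stronger inhibition of growth and higher numbers for weaker inhibition of growth), compound 1 `CCOC(=O)c1nn(-c2ccccc2)c(-c2ccc(OC)cc2)c1CNC(C)(C)C` gives 47 nM; 17100 nM (2 entries) in two entries that lie far apart. Compound 2 `CC(C)(C)NCc1c(C(=O)O)nn(-c2ccccc2)c1-c1ccccc1` stands at > 716000 nM which is a limit of the assay and not a number. Compound 3 `COc1ccc(-c2c(CNC(C)(C)C)c(C(=O)O)nn2-c2ccccc2)cc1` differs from compound 2 in one place: methoxy in place of hydrogen on an aromatic carbon and the phenyl becomes 4-methoxyphenyl. Among the compounds with values here, no measured pair shows this change on its own. In this assay only a small gain in growth inhibition is expected, perhaps none beyond the scatter. The estimate gives an at least 2.3-fold lower number from compound 2 to compound 3 (0.37 log units; beyond the scatter) as the expected step. Compound 3 is expected near 300000 nM (estimated range 60000 nM to 900000 nM).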

Compound 3, concentration for 50% growth inhibition: > 659000 nM
Compound 3 ended at the assay's limit; the forecaster's own chance of this, stated with the estimate: 55%; middle value at least 2.1-fold (0.34 log units) from the limit.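

No step can be read from compound 2 to compound 3, as each compound's value is a limit of the assay and not a number. The compounds shown leave open whether methoxy in place of hydrogen changes growth inhibition in this assay at all.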